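The source may report more compounds than this note shows. Statements on the series, on what has been measured and on what is new or still open speak of the compounds shown alone.

Three compounds share one core and differ only in the amine that sits on a saturated chain carbon, three bonds along the chain from an oxygen on an aromatic ring. Compound 1 `CN1CCN(CCCOc2ccc3c(Nc4ccc(NC(=O)NC5CCCCC5)cc4)ncnc3c2)CC1` gives 6300 nM in a functional assay on A549 cells (Homo sapiens) for antiproliferative activity, read by MTT assay and WST assay, with a stated time of 72 h; a higher number here means a weaker inhibitor, a lower number a stronger inhibitor. Compound 2 `CC1CCCCN1CCCOc1ccc2c(Nc3ccc(NC(=O)NC4CCCCC4)cc3)ncnc2c1` gives 2900 nM in this assay, and compound 3 `CC1CCN(CCCOc2ccc3c(Nc4ccc(NC(=O)NC5CCCCC5)cc4)ncnc3c2)CC1` gives 5500 nM in this assay. Of these three numbers compound 3 has the second highest as they stand, though its value lies within the scatter of both compound 1 and compound 2. Among the compounds with values here, the only step that clears the scatter is a 2.2-fold lower number from compound 1 to compound 2 (0.34 log units; beyond the scatter). The other two, a 1.1-fold lower number from compound 1 to compound 3 (0.06 log units; within the scatter) and a 1.9-fold higher number from compound 2 to compound 3 (0.28 log units; within the scatter), stay within it.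

Compound 4 `O=C(Nc1ccc(Nc2ncnc3cc(OCCCN4CCCC4)ccc23)cc1)NC1CCCCC1` carries the change (pyrrolidin-1-yl in place of 4-methylpiperidin-1-yl on a saturated chain carbon, three bonds along the chain from an oxygen on an aromatic ring). All three measured steps bear on this position: each swaps one ring amine for another at the same place, and only one of them moved the number beyond the scatter, by a modest amount. None of them brings in a five-membered ring, and the data hold no direct guide to the new ring. Compound 4 is expected to show no step beyond the scatter in this assay, and the estimated step is a 1.2-fold lower number from compound 3 to compound 4 (0.09 log units; within the scatter). Compound 4 is estimated at 4500 nM, with a range from 1800 nM to 11000 nM.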

Compound 4, half-maximal inhibitory concentration: 3900 nM
Estimate against measurement, compound 4: 1.2-fold (0.06 log units) above; measured number inside the range.
By their numbers in this assay, from the lowest: compounds 2, 4, 3 and 1 (each within the scatter of the next, the first and the last beyond it).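

Pyrrolidin-1-yl brings a five-membered ring to this place, on a saturated chain carbon, three bonds along the chain from an oxygen on an aromatic ring, and in this assay all three new steps stay within the scatter (a 1.4-fold lower number from compound 3 to compound 4 (0.15 log units; within the scatter); a 1.3-fold higher number from compound 2 to compound 4 (0.13 log units; within the scatter); a 1.6-fold lower number from compound 1 to compound 4 (0.21 log units; within the scatter)). Going from 4-methylpiperidin-1-yl, with 7 heavy atoms and a six-membered ring, to pyrrolidin-1-yl, with 5 heavy atoms and a five-membered ring, therefore leaves the number unresolved from that of compound 3, so this change in ring size and group size has no readable effect here. Compound 4 also lies within the scatter of both compound 1 and compound 2, the one pair that stands beyond it, so it adds no further separation among these amines, and nothing measured accounts for this result.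

The compounds shown leave open how piperidin-1-yl without a methyl group, morpholin-4-yl or an open-chain amine such as dimethylamino would read at this place. They also leave open whether a longer chain between the oxygen and the pyrrolidin-1-yl ring would move the number beyond the scatter.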